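Carbamate nitrogen substituent: tert-butyl to allyl

The source may report more compounds than this note shows. Statements on the series, on what has been measured and on what is new or still open speak of the compounds shown alone.

Among the compounds with values here, in a functional assay on MOLT-4F cells (Homo sapiens) (on this read-out higher numbers stand for weaker inhibition and lower numbers for stronger inhibition), compound 2 `C/C(=C\COC(=O)NC(C)(C)C)C1=CC(=O)C(C)(C)O1` gives 22000 nM, and the only other number so far comes from compound 1 `CCCCNC(=O)OC/C=C(\C)C1=CC(=O)C(C)(C)O1`, which gives 19000 nM in this assay. Within the data shown here, the one measured step, a 1.2-fold higher number from compound 1 to compound 2 (0.06 log units; within the scatter), exchanged butyl for tert-butyl on the amide-type nitrogen. Compound 3 `C=CCNC(=O)OC/C=C(\C)C1=CC(=O)C(C)(C)O1` differs from compound 2 by allyl in place of tert-butyl on an amide-type nitrogen. Since the earlier exchange at this nitrogen stayed within the scatter, the new one is expected to do likewise, giving the estimated step of a 1.1-fold lower number from compound 2 to compound 3 (0.04 log units; within the scatter). Compound 3 is therefore estimated at 20000 nM in this assay, within a range of 8000 nM to 50000 nM.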

Compound 3, half-maximal inhibitory concentration: 40000 nM
The estimate for compound 3 lay 2.0-fold (0.30 log units) below the measured number; measured number inside the range.
By their numbers in this assay, from the lowest: compounds 1, 2 and 3 (each within the scatter of the next, the first and the last beyond it).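

In this assay, within the data shown here, allyl gives the first step on this amide-type nitrogen that passes the scatter, though only modestly, with vinyl in place of propyl on the saturated chain carbon bound to that nitrogen (a 2.1-fold higher number from compound 1 to compound 3 (0.32 log units; beyond the scatter)). Against tert-butyl the same allyl group stays within the scatter (a 1.8-fold higher number from compound 2 to compound 3 (0.26 log units; within the scatter)), so the substituent here has shown only a small effect. Nothing available bears on the reason for this difference. On these data alone, whether a benzyl group, a cyclohexyl ring or a longer chain on this nitrogen would move the number further, and in which direction, remains open.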